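Dropping the Acetoxy Group From Compound 2

The compounds below may be only part of what the source reports. "The series", "measured", "known", "first", "only" and "open" are said of these compounds alone.

Of the compounds shown here, three sharing one core have been measured in an assay on membranes from brain for displacement of a labelled ligand from Neuronal acetylcholine receptor; alpha4/beta2 (Rattus norvegicus), with a stated time of 3 h; on this read-out higher numbers stand for weaker inhibition and lower numbers for stronger inhibition. Compound 1 `COc1cc(OC)c(/C=C2\CCCN=C2c2cccnc2)c(OC)c1` gives 60 nM, compound 2 `COc1ccc(/C=C2\CCCN=C2c2cccnc2)c(OC(C)=O)c1` gives 770 nM, and compound 3 `Cc1cc(C)c(/C=C2\CCCN=C2c2cccnc2)c(C)c1` gives 520 nM. Compound 2 stands at the highest of the three numbers; its gap to compound 3 is within the usual scatter, while compound 1 sits well beyond the scatter with a much lower number.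

Compound 4 `COc1ccc(/C=C2\CCCN=C2c2cccnc2)cc1` has not yet been measured. It differs from compound 2 in one place: hydrogen in place of acetoxy on an aromatic carbon, leaving only the methoxy group on that ring. Going by the values given here, no step between measured compounds follows the same change, so the direction has to be guessed from what the three numbers show. Compound 1 and compound 3 both carry groups ortho to the large group, yet give very different numbers, so such groups alone do not decide potency. The most cautious expectation is a step from compound 2 to compound 4 of a 1.9-fold lower number from compound 2 to compound 4 (0.28 log units; within the scatter) in this assay, only barely beyond the scatter. Compound 4 is therefore estimated at 400 nM, between 100 nM and 1600 nM.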

Compound 4, inhibition constant: 490 nM
Compound 4: middle estimate off by 1.2-fold (0.09 log units), on the low side; measured number inside the range.
By their numbers in this assay, from the lowest: compound 1; then compounds 4, 3 and 2 (each within the scatter of the next).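

In this assay, putting hydrogen in place of acetoxy on this aromatic carbon, ortho to a large group, gives a 1.6-fold lower number from compound 2 to compound 4 (0.20 log units; within the scatter). Going by these compounds alone, this is the first comparison here between two compounds that differ in one place, and it shows that the acetoxy group, with its 4 heavy atoms and 2 hydrogen-bond acceptors, can leave this position with the two numbers staying within the usual scatter of each other. No measured evidence bears on this result.

From the compounds shown here alone, whether an amine, a carboxylic acid or a longer chain at the same position would also stay within the scatter of hydrogen remains open. Also open, going by these compounds, is whether a methoxy group on this carbon, with everything else kept as in compound 4, would move the number beyond the scatter.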